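The compounds below may be only part of what the source reports. "The series", "measured", "known", "first", "only" and "open" are said of these compounds alone.

Working notes on the series. For the measured compounds named here, compound 2 `COc1cc(-c2nn(-c3cccc(NC(=O)Nc4cc(C(F)(F)F)cc(C(F)(F)F)c4)c3)cc2-c2ccncc2)ccc1Cl` is the only member with a number in a functional assay on KM12 cells (Homo sapiens) for inhibition, read by sulforhodamine B assay, with a stated time of 48 h (a lower number here means a stronger inhibitor of growth, a higher number a weaker inhibitor of growth), where compound 2 gives 1340 nM. Compound 1 `O=C(Nc1cccc(-n2cc(-c3ccncc3)c(-c3ccc(Cl)c(O)c3)n2)c1)Nc1cccc(C(F)(F)F)c1` carries the 4-chloro-3-hydroxyphenyl and one trifluoromethyl; in this assay compound 1 reaches only a limit, > 32500 nM, as the limit of > 32500 nM in this assay, at which 1 of the 2 values shown sits, records. Compound 3 `O=C(Nc1cccc(-n2cc(-c3ccncc3)c(-c3ccc(Cl)c(O)c3)n2)c1)Nc1cc(C(F)(F)F)cc(C(F)(F)F)c1` is not yet measured and differs from compound 2 by hydrogen in place of methyl on an oxygen on an aromatic ring. Going by the values given here, no measured step covers this change. Compound 3 shares the hydroxy with compound 1, for which no number was obtained. A step toward weaker inhibition, beyond the scatter, is therefore expected, a 6.0-fold higher number from compound 2 to compound 3 (0.78 log units; beyond the scatter). Compound 3 is estimated at 8000 nM, between 2000 nM and 32500 nM, with a fair chance of a limit only.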

Compound 3, concentration for total growth inhibition: 1430 nM
Beside the measured number, compound 3's estimate is 5.6-fold (0.75 log units) above it; measured number below the stated range.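

Methoxy to hydroxy on the oxygen on the aromatic ring does not separate the compounds in this assay, with a 1.1-fold higher number from compound 2 to compound 3 (0.03 log units; within the scatter) as the step. With the hydroxy kept, the large step lies at the aromatic carbon, where trifluoromethyl takes the place of hydrogen, with an at least 22-fold lower number from compound 1 to compound 3 (1.35 log units; beyond the scatter) as the step. Compound 1 gives only a limit, so this step is a bound: the limit of > 32500 nM in this assay, at which 1 of the 3 values shown sits.

From the compounds shown here alone, whether a nitrile or a methyl on that aromatic carbon would read like trifluoromethyl stays open. Also open, going by these compounds, is how an ethoxy or an amine would read in place of the hydroxy.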